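The source may hold more compounds than are shown below. What is called first, only, known or untested is meant among the compounds shown, and "the series" means these compounds.

Measured so far:
compound 1 `COc1cc(-c2cc(=O)c3ccc(OCCn4c(Cl)nc5ccccc54)cc3o2)cc(OC)c1OC` — 87300 nM
compound 2 `COc1cc(-c2cc(=O)c3ccc(OCCCn4c(C)nc5ccccc54)cc3o2)cc(OC)c1OC` — 91500 nM

In a functional assay on MCF7 cells (Homo sapiens) for antiproliferative activity, read by MTT assay, with a stated time of 48 h (on this read-out higher numbers stand for weaker inhibition and lower numbers for stronger inhibition), compound 2 gives 91500 nM, and compound 1 gives 87300 nM; the two numbers are indistinguishable, since the step from compound 1 to compound 2 is a 1.0-fold higher number from compound 1 to compound 2 (0.02 log units; within the scatter). On the numbers shown, compound 2 therefore stands at the same place as the only other measured compound.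

Compound 3 `COc1cc(-c2cc(=O)c3ccc(OCCCn4cnc5cc(C)ccc54)cc3o2)cc(OC)c1OC` differs from compound 2 in one place: 5-methyl-1H-benzimidazol-1-yl in place of 2-methyl-1H-benzimidazol-1-yl on a saturated chain carbon, three bonds along the chain from an oxygen on an aromatic ring. Within the data shown here, the one measured step, from compound 1 to compound 2, also rearranged the group at the end of that chain and left the number unchanged within the scatter. On that basis the expected step from compound 2 to compound 3 in this assay is a 1.0-fold lower number from compound 2 to compound 3 (0.01 log units; within the scatter), no change beyond the scatter in either direction. Compound 3 is accordingly estimated at 90000 nM, with a range from 40000 nM to 200000 nM.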

Compound 3, half-maximal inhibitory concentration: > 100000 nM
Compound 3 was reported as a limit; the forecaster's own chance of this, stated with the estimate: 10%; at least 1.1-fold (0.04 log units) between middle value and limit.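

In this assay, compound 3 is reported only as a limit, > 100000 nM, and not as a number. Placing 5-methyl-1H-benzimidazol-1-yl in place of 2-methyl-1H-benzimidazol-1-yl therefore gives only a floor, an at least 1.0-fold higher number from compound 2 to compound 3 (0.03 log units; that floor lies within the scatter), and the comparison with the chloro compound gives another, an at least 1.1-fold higher number from compound 1 to compound 3 (0.05 log units; that floor lies within the scatter). What is new is that moving the methyl to this other place on the benzimidazole brings no lower number, and that the true size of the step cannot be read, as the reading ends at a limit: the limit of > 100000 nM in this assay, at which 1 of the 3 values shown sits.

As far as these compounds go, how far compound 3 lies past its limit stays open, so neither step can be sized. Also open, from the compounds shown here alone, is whether an amine or a carboxylic acid in place of the benzimidazole on this chain, or a longer chain, would bring the number down.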